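Methyl added to the shared core of compound 1

A few compounds are considered here, and "the series" means these few. Any claim that something is new, unique, unknown or untested is made for them only; others in the source may bear on it.

compound 1 `O=C1c2ccccc2C(=O)N1CCOC(=S)N(C(=O)c1cccc([N+](=O)[O-])c1)c1ccc(Cl)cc1`: 18000 nM
compound 2 `O=C1c2ccccc2C(=O)N1CCOC(=S)N(C(=O)c1cc([N+](=O)[O-])ccc1Cl)c1ccc(Cl)cc1`: 45000 nM
compound 3 `Cc1cc(C(=O)N(C(=S)OCCN2C(=O)c3ccccc3C2=O)c2ccc(Cl)cc2)ccc1Br`: 18000 nM

In an ADME assay on MT4 cells (Homo sapiens) for cytotoxicity, read by MTT assay (a higher number here means that more compound is tolerated, a lower number that less compound is tolerated), compound 3 and compound 1 stand level at 18000 nM, together the lowest of the three numbers. Compound 4 `Cc1cccc2c1C(=O)N(CCOC(=S)N(C(=O)c1cccc([N+](=O)[O-])c1)c1ccc(Cl)cc1)C2=O` differs from compound 1 by methyl in place of hydrogen on an aromatic carbon. Among the compounds with values here, no measured step changes that ring. The closest guides lie elsewhere in the molecule: chloro in place of hydrogen on an aromatic carbon gave a 2.5-fold higher number from compound 1 to compound 2 (0.40 log units; beyond the scatter), and 4-bromo-3-methylphenyl in place of 3-nitrophenyl gave no change at the digits printed from compound 1 to compound 3 (within the scatter). Neither step sets a direction, so none beyond the scatter is expected in this assay. The expected step is a 1.1-fold higher number from compound 1 to compound 4 (0.05 log units; within the scatter). For compound 4 the estimated value is 20000 nM, expected to fall between 9000 nM and 45000 nM.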

Compound 4, half-maximal cytotoxic concentration: 44000 nM
Estimate against measurement, compound 4: 2.2-fold (0.34 log units) below, within the range that was stated.
By their numbers in this assay, from the lowest: compounds 1 and 3 (each within the scatter of the next); then compounds 4 and 2 (each within the scatter of the next).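

In this assay, methyl in place of hydrogen on the shared core gives a 2.4-fold higher number from compound 1 to compound 4 (0.39 log units; beyond the scatter). Within the data shown here, this modest step shows that the number responds to a change on this six-membered aromatic ring, ortho to a fused ring and meta to a fused ring, whereas the earlier steps all lay on the aromatic ring attached to the carbonyl carbon. No measurement on hand bears on the reason for this step. Open, from the compounds shown here alone, is whether an amine or a methoxy group on this carbon would move the number in the same direction, and whether a longer chain would extend the step.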